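This account rests on a few compounds, and the source may have more. Where it says the series, first, only, none or still open, it means among the compounds named here.

Compound 1 `O=C(Nc1cccc(-n2cc(-c3ccncc3)c(-c3ccc(Cl)c(O)c3)n2)c1)Nc1cccc(C(F)(F)F)c1` links the shared core through a urea to a 3-(trifluoromethyl)phenyl group. In a functional assay on HOP-62 cells (Homo sapiens) for inhibition, read by sulforhodamine B assay, with a stated time of 48 h (on this read-out lower numbers stand for higher toxicity in this test and higher numbers for lower toxicity in this test), compound 1 gives only a limit of the assay, > 32500 nM. Compound 2 `COc1cc(-c2nn(-c3cccc(NC(=O)Nc4cccc(C(F)(F)F)c4)c3)cc2-c2ccncc2)ccc1Cl` likewise reaches only a limit in this assay, > 50000 nM. The step that the two limits leave unreadable from compound 1 to compound 2 therefore cannot be sized, as both the limit of > 32500 nM in this assay, at which 1 of the 3 values shown sits, and the limit of > 50000 nM in this assay, at which 1 of the 3 values shown sits, are involved. Compound 3 `O=C(Nc1cccc(-n2cc(-c3ccncc3)c(-c3ccc(Cl)c(O)c3)n2)c1)Nc1cc(C(F)(F)F)cc(C(F)(F)F)c1` gives 4070 nM, and the step of an at least 7.9-fold lower number from compound 1 to compound 3 (0.90 log units; beyond the scatter) shows that this change lowers the number at least modestly.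

Compound 4 `O=C(Nc1cccc(-n2cc(-c3ccncc3)c(-c3ccc(Cl)c(O)c3)n2)c1)Nc1ccc(Cl)c(C(F)(F)F)c1` differs from compound 1 by chloro in place of hydrogen on an aromatic carbon. Within the data shown here, the only readable step, an at least 7.9-fold lower number from compound 1 to compound 3 (0.90 log units; beyond the scatter), concerns a different group at a different place, so it is a loose guide at best, and a step that the two limits leave unreadable from compound 1 to compound 2 offers nothing. With compound 1 sitting at a limit, only a lowering could be seen at all. An at least modest lowering is expected, an at least 2.1-fold lower number from compound 1 to compound 4 (0.33 log units; beyond the scatter), though a further limit remains quite possible. Compound 4 is therefore estimated at 15000 nM, within a range from 4000 nM to 50000 nM.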

Compound 4, concentration lethal to 50% of the cells: > 32500 nM
Compound 4: only a limit was reported; the forecaster's own chance of this, stated with the estimate: 40%; middle value at least 2.1-fold (0.33 log units) from the limit.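

In this assay compound 4 gives only a limit, > 32500 nM. Compound 1 sits at that same limit, so no new step can be read between compound 1 and compound 4: the limit of > 32500 nM in this assay, at which 2 of the 4 values shown sit. The compounds shown leave open whether chloro in place of hydrogen at this place changes the number at all.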